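A Tert-Butyl Group Added to an Inactive Compound

The source may report more compounds than this note shows. Statements on the series, on what has been measured and on what is new or still open speak of the compounds shown alone.

Compound 1 (`O=C(O)CC(NC(=O)c1c(Cl)cccc1Cl)c1ccccc1`) has no exact potency on record, only a limit. In a functional assay on MDA-MB-231 cells (Homo sapiens) for antiproliferative activity, read by MTT assay, with a stated time of 24 h (on this read-out higher numbers stand for weaker inhibition and lower numbers for stronger inhibition), compound 1 gives > 100000 nM, and this value is a limit of the assay. Compound 2 (`N#Cc1ccc(S(=O)(=O)NC(CC(=O)O)c2ccccc2)cc1`), which carries a different structure, does give a number in this assay, at 48700 nM. Compound 3 (`CC(C)(C)c1ccc(C(CC(=O)O)NC(=O)c2c(Cl)cccc2Cl)cc1`) keeps the rest of compound 1 but has tert-butyl in place of hydrogen on an aromatic carbon, para to a large group: tert-butyl in place of hydrogen on an aromatic carbon. Going by the values given here, no measured pair shows what this change does, so any forecast is uncertain, and compound 3 may also return only a limit. The expected change is modest, toward stronger inhibition, and is estimated as an at least 1.6-fold lower number from compound 1 to compound 3 (0.22 log units; that floor lies within the scatter). The estimated value for compound 3 is 60000 nM, with an expected range of 20000 nM to 150000 nM.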

Compound 3, half-maximal inhibitory concentration: > 100000 nM
Compound 3: only a limit was reported; the forecaster's own chance of this, stated with the estimate: 45%; middle value at least 1.6-fold (0.22 log units) from the limit.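

Compound 3, like compound 1, returns only a limit in this assay, so no step between the two compounds can be read: the limit of > 100000 nM in this assay, at which 2 of the 3 values shown sit.

The compounds shown leave open whether tert-butyl in place of hydrogen on an aromatic carbon changes the inhibition at all.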